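Substituents on the ring-nitrogen phenyl: compound 3 to compound 4

The source may hold more compounds than are shown below. What is called first, only, known or untested is meant among the compounds shown, and "the series" means these compounds.

Three measured compounds share one core and differ only in the aryl group on the amine nitrogen in the ring. In a functional assay on HL-60 cells (Homo sapiens) for inhibition, read by MTT assay, with a stated time of 72 h (a lower number here means a stronger inhibitor, a higher number a weaker inhibitor), compound 1 `Cc1nc(-c2ccccc2)c(C(=O)N2CCN(c3cccc(Cl)c3Cl)CC2)o1` gives 133 nM. Compound 2 `Cc1nc(-c2ccccc2)c(C(=O)N2CCN(c3ccccc3Cl)CC2)o1` gives 124 nM in this assay. Compound 3 `Cc1nc(-c2ccccc2)c(C(=O)N2CCN(c3ccccc3)CC2)o1` gives 39.1 nM in this assay, the lowest of the three numbers, with both of its steps from the other two compounds beyond the scatter. Among the measured steps, a 1.1-fold lower number from compound 1 to compound 2 (0.03 log units; within the scatter); a 3.4-fold lower number from compound 1 to compound 3 (0.53 log units; beyond the scatter); a 3.2-fold lower number from compound 2 to compound 3 (0.50 log units; beyond the scatter).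

Compound 4 `Cc1cc(C)cc(N2CCN(C(=O)c3oc(C)nc3-c3ccccc3)CC2)c1` has not yet been measured in this assay. Its change from compound 3 is 3,5-dimethylphenyl in place of phenyl on an amine nitrogen in a ring. Within the data shown here, no measured step places methyl on this aryl group, so the two chloro steps are the only guide: each time a substituent sat on the phenyl, the number was modestly higher than for compound 3 at 39.1 nM. A small rise is therefore expected for compound 4, possibly within the scatter, since a different substituent pattern need not behave as chloro did. The estimated step from compound 3 is a 1.8-fold higher number from compound 3 to compound 4 (0.25 log units; within the scatter). For compound 4 the expected value in this assay is 70 nM, with a range from 25 nM to 200 nM.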

Compound 4, half-maximal inhibitory concentration: 34.5 nM
Estimate against measurement, compound 4: 2.0-fold (0.31 log units) above; the range from low to high includes it.
By their numbers in this assay, from the lowest: compounds 4 and 3 (each within the scatter of the next); then compounds 2 and 1 (each within the scatter of the next).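

Notes on the aryl group on the amine nitrogen in the ring: in this assay, substitution on the phenyl does not by itself go with a higher number, as the step to 3,5-dimethylphenyl is a 1.1-fold lower number from compound 3 to compound 4 (0.05 log units; within the scatter). The two chloro compounds therefore no longer speak for substituents on this phenyl in general, since compound 4 stands apart from both, with a 3.6-fold lower number from compound 2 to compound 4 (0.56 log units; beyond the scatter) and a 3.9-fold lower number from compound 1 to compound 4 (0.59 log units; beyond the scatter), while compound 3 and compound 4 sit level within the scatter. No measurement shown accounts for this difference between the methyl-bearing and chloro-bearing aryl groups.

The 3,5-dimethylphenyl group differs from 2-chlorophenyl and 2,3-dichlorophenyl both in the substituent and in where it sits on the phenyl, so the compounds shown cannot separate these two changes, and a 3,5-dichlorophenyl group would be the direct test. Also open, from the compounds shown here alone, is whether methoxy, a carboxylic acid or an amine on this phenyl would stay level with compound 3 and compound 4 or would follow the chloro compounds.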